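Hydrazone aryl variation on the shared core

The source may hold more compounds than are shown below. What is called first, only, known or untested is meant among the compounds shown, and "the series" means these compounds.

Compound 3 `O=C(Cc1csc2nc(-c3ccc(Br)cc3)cn12)N/N=C/c1ccc(O)cc1` gives 29500 nM in a functional assay on HCC 2998 cells (Homo sapiens) for inhibition, read by sulforhodamine B assay, with a stated time of 48 h (a higher number here means a weaker inhibitor of growth, a lower number a stronger inhibitor of growth), the second highest of the three numbers recorded: compound 1 `O=C(Cc1csc2nc(-c3ccc(Br)cc3)cn12)N/N=C/c1ccccc1` gives 49000 nM and compound 2 `O=C(Cc1csc2nc(-c3ccc(Br)cc3)cn12)N/N=C/c1ccccc1O` gives 12600 nM. The steps of a 1.7-fold lower number from compound 1 to compound 3 (0.22 log units; within the scatter) and a 2.3-fold higher number from compound 2 to compound 3 (0.37 log units; beyond the scatter) frame where compound 3 stands. Compound 4 `O=C(Cc1csc2nc(-c3ccc(Br)cc3)cn12)N/N=C/c1ccc(Cl)cc1Cl` differs from compound 3 by 2,4-dichlorophenyl in place of 4-hydroxyphenyl on a carbon with a double bond to nitrogen. For the measured compounds named here, the only step bearing on the leaving group is a 1.7-fold lower number from compound 1 to compound 3 (0.22 log units; within the scatter), which shows that the hydroxy group hardly moved the number, so its loss is expected to cost little; no measured step covers the dichloro substitution, so that part of the change is open. For compound 4 the expected step is a 1.2-fold higher number from compound 3 to compound 4 (0.07 log units; within the scatter), not beyond the scatter. Compound 4 is therefore expected at 35000 nM, within 10000 nM to 100000 nM.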

Compound 4, concentration for total growth inhibition: 44700 nM
Beside the measured number, compound 4's estimate is 1.3-fold (0.11 log units) below it; the range from low to high includes it.
By their numbers in this assay, from the lowest: compound 2; then compounds 3, 4 and 1 (each within the scatter of the next).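

Against phenyl and 4-hydroxyphenyl, the 2,4-dichlorophenyl group shows a 1.1-fold lower number from compound 1 to compound 4 (0.04 log units; within the scatter) and a 1.5-fold higher number from compound 3 to compound 4 (0.18 log units; within the scatter) in this assay and so adds no shift beyond the scatter at this place. Against 2-hydroxyphenyl it shows a 3.5-fold higher number from compound 2 to compound 4 (0.55 log units; beyond the scatter) and leaves compound 2 as the only member of the four set apart from the others. Nothing measured here accounts for this difference.

As far as these compounds go, whether the result for compound 2 is tied to its hydroxy group stays open, and a 2-aminophenyl or 2-methoxyphenyl group at this place would test that. From the compounds shown here alone, a single chlorine on the phenyl ring also remains open, so the dichloro result cannot be divided between its two chlorines.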